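The compounds below may be only part of what the source reports. "The series", "measured", "known", "first", "only" and "open" are said of these compounds alone.

Compound 1 `O=C(CSc1nnc(-c2ccncc2)o1)N/N=C/c1ccc(O)cc1` gives 158000 nM in an ADME assay on NIH3T3 cells (Mus musculus) for cytotoxicity, read by MTT assay, with a stated time of 24 h; on this read-out higher numbers stand for weaker inhibition and lower numbers for stronger inhibition.
Compound 2 `O=C(CSc1nnc(-c2ccncc2)o1)N/N=C/c1cccc(F)c1` gives 205000 nM in this assay.
Compound 3 `O=C(CSc1nnc(-c2ccncc2)o1)N/N=C/c1ccccc1O` gives 155000 nM in this assay.

Of the three numbers, compound 3 shows the smallest, but a 1.0-fold lower number from compound 1 to compound 3 (0.01 log units; within the scatter) and a 1.3-fold lower number from compound 2 to compound 3 (0.12 log units; within the scatter), so on these measurements the three compounds cannot be told apart. Compound 4 `COc1cc(/C=N/NC(=O)CSc2nnc(-c3ccncc3)o2)ccc1O` has not yet been measured. It differs from compound 3 in one place: 4-hydroxy-3-methoxyphenyl in place of 2-hydroxyphenyl on a carbon with a double bond to nitrogen. The measured steps all swap the aryl group on that same carbon; a 1.3-fold higher number from compound 1 to compound 2 (0.11 log units; within the scatter), a 1.0-fold lower number from compound 1 to compound 3 (0.01 log units; within the scatter) and a 1.3-fold lower number from compound 2 to compound 3 (0.12 log units; within the scatter), each within the scatter. Every change of this kind seen so far has left the number in this assay essentially where it was, so for compound 4 no step beyond the scatter is expected in either direction, and the expected step is a 1.0-fold higher number from compound 3 to compound 4 (0.01 log units; within the scatter). Compound 4 is therefore estimated to give 160000 nM in this assay, with a range from 75000 nM to 340000 nM.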

Compound 4, half-maximal inhibitory concentration: 148000 nM
For compound 4 the middle estimate is 1.1-fold (0.03 log units) above the measured one; the measured number falls inside the stated range.
By their numbers in this assay, from the lowest: compounds 4, 3, 1 and 2 (each within the scatter of the next).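

Compound 4 shows what adding a methoxy group in place of a hydrogen on an aromatic carbon does, since a 1.1-fold lower number from compound 1 to compound 4 (0.03 log units; within the scatter) is the step seen in this assay for that single addition. Swapping the whole aryl group gives the same picture: a 1.0-fold lower number from compound 3 to compound 4 (0.02 log units; within the scatter) and a 1.4-fold lower number from compound 2 to compound 4 (0.14 log units; within the scatter) show that 4-hydroxy-3-methoxyphenyl, with more heavy atoms and hydrogen-bond acceptors than 2-hydroxyphenyl, still cannot be told apart from the other groups at this position. Nothing at hand explains why the number stays put.

Still open, on these data alone, is whether a different kind of substituent on the aryl group, such as an amine or a carboxylic acid, would move the number beyond the scatter. Every step shown lies on the aryl group, so how the number responds to changes in the shared core also stays open.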